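Extending the Methoxy of Compound 3 to Propoxy

A few compounds are considered here, and "the series" means these few. Any claim that something is new, unique, unknown or untested is made for them only; others in the source may bear on it.

In a functional assay on MDCK cells (Canis lupus familiaris) for inhibition (on this read-out higher numbers stand for lower toxicity in this test and lower numbers for higher toxicity in this test), compound 1 `Cn1c(CC23CCCC[C@@H]2O3)cc(=O)n(C)c1=O` gives 40000 nM. Compound 3 `COc1nc(CC2(c3ccccc3)CCCO2)cc(=O)n1C` gives 130000 nM, the higher of these two numbers, and the gap between them lies beyond the scatter. Compound 2 `CCCOc1nc(CC2(c3ccccc3)CO2)cc(=O)n1C`, which carries a propoxy, reads > 330000 nM, a limit of the assay and not a number. Compound 4 `CCCOc1nc(CC2(c3ccccc3)CCCO2)cc(=O)n1C` differs from compound 3 by ethyl in place of hydrogen on a saturated chain carbon bound to an oxygen on an aromatic ring, a change of methoxy to propoxy. Going by the values given here, no measured pair isolates this change, so no step beyond the scatter is expected in this assay, and the expectation rests on compound 3 at 130000 nM. The expected step of a 1.2-fold higher number from compound 3 to compound 4 (0.09 log units; within the scatter) is estimated to stay within the scatter. For compound 4 the estimated value is 160000 nM, with an expected range of 70000 nM to 330000 nM.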

Compound 4, half-maximal cytotoxic concentration: 170000 nM
Estimate against measurement, compound 4: 1.1-fold (0.03 log units) below, and the stated range covers the measured number.
By their numbers in this assay, from the lowest: compound 1; then compounds 3 and 4 (each within the scatter of the next). At a limit, above all of these: compound 2.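

In this assay the change of methoxy to propoxy gives a 1.3-fold higher number from compound 3 to compound 4 (0.12 log units; within the scatter) at this place, a saturated chain carbon bound to an oxygen on an aromatic ring. For this one pair, the added ethyl leaves the read-out within the scatter. Both compounds give numbers, and neither stands at the one limit shown: the limit of > 330000 nM in this assay, at which 1 of the 4 values shown sits. The compounds shown leave open how an amine, a carboxylic acid or a longer chain would read at this place. They also leave open whether the same change stays within the scatter on other cores.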